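The compounds below may be only part of what the source reports. "The series", "measured", "known", "first", "only" and "open" are said of these compounds alone.

Compound 1 `Cc1cc(=O)oc2cc(OCc3cn(-c4ccc(F)c(Cl)c4)nn3)ccc12`: > 100 ug/mL
Compound 2 `Cc1cc(=O)oc2cc(OCc3cn(-c4ccc(F)cc4)nn3)ccc12`: > 100 ug/mL

In an ADME assay on Huh-7 cells (Homo sapiens) for cytotoxicity, read by MTT assay, with a stated time of 72 h (on this read-out higher numbers stand for lower toxicity in this test and lower numbers for higher toxicity in this test), compound 1 gives > 100 ug/mL, which is a limit of the assay and not a number. Compound 2 gives > 100 ug/mL, which is likewise a limit. Compound 1 therefore stands at the limit of > 100 ug/mL in this assay, at which 2 of the 2 values shown sit, and no exact value is known for it.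

Compound 3 `Cc1cc(=O)oc2cc(OCc3cn(-c4cccc(F)c4)nn3)ccc12` has not yet been measured. It carries 3-fluorophenyl in place of 3-chloro-4-fluorophenyl on an aromatic nitrogen. Going by the values given here, the one measured step that bears on this change is a step that the two limits leave unreadable from compound 1 to compound 2, which also removes the chloro group, and its size cannot be read. That step gives no sign of a change in either direction, so no step beyond the scatter is expected in this assay. The estimated step is a step that the limit leaves unreadable from compound 1 to compound 3. For compound 3 the expected value is 130 ug/mL, with an estimated range from 70 ug/mL to 300 ug/mL. The assay is expected to report a limit again rather than a number.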

Compound 3, half-maximal cytotoxic concentration: > 100 ug/mL
Compound 3 gave a limit, no number; the forecaster's own chance of this, stated with the estimate: 80%; the middle value does not contradict the limit.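

In this assay compound 3 gives > 100 ug/mL as a limit and not a number. The steps from compound 1 to compound 3 and from compound 2 to compound 3 therefore cannot be read, and all three compounds share one limit: the limit of > 100 ug/mL in this assay, at which 3 of the 3 values shown sit. The compounds shown leave open whether these changes on the phenyl group alter the half-maximal cytotoxic concentration at all.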